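A few compounds are considered here, and "the series" means these few. Any claim that something is new, unique, unknown or untested is made for them only; others in the source may bear on it.

Measured compounds:
- compound 1, `O=C(N/N=C/c1cccc(Cl)c1Cl)Nc1ccc(Oc2ccnc3[nH]ccc23)c(F)c1`: "not active" (no number reported)
- compound 2, `O=C(N/N=C/c1ccc(O)cc1)Nc1ccc(Oc2ccnc3[nH]ccc23)c(F)c1`: 1950 nM
- compound 3, `O=C(N/N=C/c1cccc(Cl)c1Cl)Nc1ccc(Oc2ccnc3[nH]ccc23)cc1`: "not active" (no number reported)

The three measured compounds share a core and differ at the aryl group on the hydrazone carbon and at the fluorine on the central ring. Among the compounds with values here, in a functional assay on HepG2 cells (Homo sapiens) for antiproliferative activity, read by MTT assay, with a stated time of 72 h (a lower number here means a stronger inhibitor, a higher number a weaker inhibitor), compound 2 gives 1950 nM, the only numerical value in this set. Compound 1 and compound 3, both carrying the 2,3-dichlorophenyl group, were reported as not active in this assay without a number, so compound 3 has no figure to stand on and can only be placed among the entries without a value.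

The next compound, compound 4, `CN(C)CCCn1cccc1/C=N/NC(=O)Nc1ccc(Oc2ccnc3[nH]ccc23)cc1`, is built from compound 3 by the change (1-(3-(dimethylamino)propyl)-1H-pyrrol-2-yl in place of 2,3-dichlorophenyl on a carbon with a double bond to nitrogen). Within the data shown here, no measured pair shows this kind of exchange, so the direction of the step cannot be taken from the data. Among the measured compounds shown here, the only numerical anchor is compound 2, whose hydroxyphenyl variant gives 1950 nM; compound 3 itself gives "not active" (no number reported). Any estimate for compound 4 therefore carries wide uncertainty, with a real chance that it too returns no number. Compound 4 is expected to fall near 4000 nM, within a range from 800 nM to 20000 nM, pending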

Compound 4, half-maximal inhibitory concentration: 4190 nM
Beside the measured number, compound 4's estimate is 1.0-fold (0.02 log units) below it; low and high end bracket the measured number.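

Within the data shown here, compound 3 has no number in this assay, so no step to compound 4, at 4190 nM, can be read. From the compounds shown here alone, how far 1-(3-(dimethylamino)propyl)-1H-pyrrol-2-yl in place of 2,3-dichlorophenyl shifts activity stays open. No supporting evidence bears on this result.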